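Urea to Benzamide: Where Compound 3 Is Expected to Land

The source may report more compounds than this note shows. Statements on the series, on what has been measured and on what is new or still open speak of the compounds shown alone.

In a functional assay on OVCAR-3 cells (Homo sapiens) for inhibition, read by sulforhodamine B assay, with a stated time of 48 h, tested at 1 uM (a lower number here means a stronger effect, a higher number a weaker effect of the compound at the concentration tested), two compounds have been measured so far. Compound 1 `O=C(Nc1cccc(-n2cc(-c3ccncc3)c(-c3cc(O)cc(Cl)c3)n2)c1)Nc1ccc(Cl)c(Cl)c1` gives 85%, and compound 2 `COc1cc(Cl)cc(-c2nn(-c3cccc(NC(=O)Nc4ccc(Cl)c(Cl)c4)c3)cc2-c2ccncc2)c1` gives 61%. For the measured compounds named here, the only step between them, a number 24 percentage points lower from compound 1 to compound 2 (beyond the scatter), places compound 2 as the lower of the two numbers, with compound 1 standing higher by a margin beyond the scatter. Compound 3 `COc1cc(Cl)cc(-c2nn(-c3cccc(NC(=O)c4cccc(C(F)(F)F)c4)c3)cc2-c2ccncc2)c1` has not yet been measured. It differs from compound 2 in one place: 3-(trifluoromethyl)phenyl in place of (3,4-dichlorophenyl)amino on a carbonyl carbon. Going by the values given here, no measured step bears on this change; the single step recorded so far concerns only a methyl in place of hydrogen on an oxygen on an aromatic ring and says nothing about the carbonyl end of the molecule. With no guidance from the data, the expectation for compound 3 stays close to compound 2, and the estimated step of a number 4 percentage points higher from compound 2 to compound 3 (within the scatter) is expected to remain within the scatter. Compound 3 is therefore estimated at 65%, with a wide range from 35% to 95%.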

Compound 3, a percentage reported as activity, at one concentration (the size of the read-out at that concentration, not a potency): 102%
For compound 3 the middle estimate is 37 percentage points below the measured one; measured number above the stated range.
By their numbers in this assay, from the lowest: compound 2; then compound 1; then compound 3.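

In this assay, 3-(trifluoromethyl)phenyl in place of (3,4-dichlorophenyl)amino on the carbonyl carbon gives a number 41 percentage points higher from compound 2 to compound 3 (beyond the scatter), so the carbonyl end of the molecule, which the earlier step did not touch, clearly affects the read-out, and this change weakens the effect at the concentration tested. The change alters several features at once: the ring nitrogen link and its hydrogen-bond donor leave, the two chlorine atoms leave, and three fluorine atoms enter, so this single step cannot assign the shift to any one of them. Nothing shown explains why the number rises at this position.

The compounds shown leave open whether a 3,4-dichlorophenyl group joined directly to the carbonyl carbon, or a (3-(trifluoromethyl)phenyl)amino group in the same place, would stand closer to compound 2 or to compound 3. Also open, as far as these compounds go, are the effect of a cyclohexyl group or a carboxylic acid on that carbonyl carbon, and whether the step between hydrogen and methyl on the oxygen would carry over to the compound 3 series.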